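Swapping methanesulfonamido for ((4-fluorophenyl)carbonyl)oxy in compound 2

The compounds below may be only part of what the source reports. "The series", "measured", "known", "first", "only" and "open" are said of these compounds alone.

Compound 2 `CS(=O)(=O)NC1CCC(CN2CCN(c3cc(=O)c4cc(C(F)(F)F)cc([N+](=O)[O-])c4s3)CC2)CC1` carries a methanesulfonamido group on a saturated ring carbon. In an ADME assay on Vero cells (Chlorocebus sabaeus) for cytotoxicity, read by MTT assay, with a stated time of 48 h (a lower number here means a stronger inhibitor, a higher number a weaker inhibitor), compound 2 gives 48.5 ug/mL. Among the measured compounds shown here, that is the only plain number among the three measured compounds. Compound 1 `CS(=O)(=O)OC1CCC(CN2CCN(c3cc(=O)c4cc(C(F)(F)F)cc([N+](=O)[O-])c4s3)CC2)CC1` bears (methylsulfonyl)oxy at that carbon; in this assay compound 1 returns only a limit, > 64 ug/mL. Compound 3 `O=C(OC1CCC(CN2CCN(c3cc(=O)c4cc(C(F)(F)F)cc([N+](=O)[O-])c4s3)CC2)CC1)c1ccncc1` bears ((pyridin-4-yl)carbonyl)oxy there; in this assay compound 3 also returns a limit, > 64 ug/mL. The measured steps show an at least 1.3-fold lower number from compound 1 to compound 2 (0.12 log units; that floor lies within the scatter) and an at least 1.3-fold higher number from compound 2 to compound 3 (0.12 log units; that floor lies within the scatter), and a step that the two limits leave unreadable from compound 1 to compound 3.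

Compound 4 `O=C(OC1CCC(CN2CCN(c3cc(=O)c4cc(C(F)(F)F)cc([N+](=O)[O-])c4s3)CC2)CC1)c1ccc(F)cc1` differs from compound 2 in this way: ((4-fluorophenyl)carbonyl)oxy in place of methanesulfonamido on a saturated ring carbon. The step that bears most directly on it is an at least 1.3-fold higher number from compound 2 to compound 3 (0.12 log units; that floor lies within the scatter), since compound 3 likewise exchanges methanesulfonamido for a ((pyridin-4-yl)carbonyl)oxy group on that ring carbon, and that step reached (the limit of > 64 ug/mL in this assay, at which 2 of the 3 values shown sit). The expectation for compound 4 in this assay is therefore a step of a 1.3-fold higher number from compound 2 to compound 4 (0.12 log units; within the scatter), upward at most by an amount near the scatter, with a fair chance that only a limit is reported again. Compound 4 is estimated at 64 ug/mL, within 40 ug/mL to 100 ug/mL.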

Compound 4, half-maximal inhibitory concentration: > 64 ug/mL
Compound 4: no number, only a limit; the forecaster's own chance of this, stated with the estimate: 60%; the middle value sits exactly at the limit.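

Swapping methanesulfonamido for ((4-fluorophenyl)carbonyl)oxy on the saturated ring carbon gives, in this assay, an at least 1.3-fold higher number from compound 2 to compound 4 (0.12 log units; that floor lies within the scatter). This shows that a group with a six-membered aromatic ring of carbon only and no hydrogen-bond donor also ends at the limit of the assay, as the pyridin-4-yl group of compound 3 did, while the steps from compound 3 to compound 4 and from compound 1 to compound 4 cannot be read, as both ends of each are limits. Among the groups at this position, all three joined through oxygen now share that reading and only the methanesulfonamido group of compound 2 gives a plain number: the limit of > 64 ug/mL in this assay, at which 3 of the 4 values shown sit.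

As far as these compounds go, how far compound 1, compound 3 and compound 4 actually lie from the limit stays unknown, so any difference among them remains hidden, and the floor of the step from compound 2 does not show that a real change exists at all. From the compounds shown here alone, whether an amine or a carboxylic acid on that saturated ring carbon would give a plain number in this assay also remains open.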